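This account rests on a few compounds, and the source may have more. Where it says the series, first, only, none or still open, it means among the compounds named here.

Of the compounds shown here, three have been tested in an ADME assay on HepG2 cells (Homo sapiens) for cytotoxicity (on this read-out higher numbers stand for lower toxicity in this test and lower numbers for higher toxicity in this test), and none gave an exact number. Compound 1 (`Fc1cccc(COc2ccc(Nc3ncnc4cc(C#CC5CCCC5)sc34)cc2Cl)c1`) reads > 31 uM, which is a limit of the assay. Compound 2 (`CC(C)(C)OC(=O)N1CCN(CC#Cc2cc3ncnc(Nc4ccc(OCc5cccc(F)c5)c(Cl)c4)c3s2)CC1`) reads > 24 uM, also a limit. On these data alone, compound 3 (`CC(C)(C)CC#Cc1cc2c(Nc3ccc(OCc4cccc(F)c4)c(Cl)c3)ncnc2s1`) reads > 32 uM, again only a limit, so its exact place among the three is unknown. Compound 4 (`COCC#Cc1cc2c(Nc3ccc(OCc4cccc(F)c4)c(Cl)c3)ncnc2s1`) has methoxy in place of tert-butyl on a saturated chain carbon bound to a triple-bonded carbon. For the measured compounds named here, no measured step guides this change, so no shift beyond the usual scatter is expected in either direction. The expected step is an at least 1.0-fold lower number from compound 3 to compound 4 (0.02 log units; that floor lies within the scatter). For compound 4 the estimate is 30 uM, with an expected range of 14 uM to 60 uM.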

Compound 4, half-maximal toxic concentration: 9.5 uM
For compound 4 the middle estimate is 3.2-fold (0.50 log units) above the measured one; measured number outside the range, below it.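

In this assay, the group on a saturated chain carbon bound to a triple-bonded carbon proves able to move the read-out: methoxy in place of tert-butyl gives an at least 3.3-fold lower number from compound 3 to compound 4 (0.52 log units; beyond the scatter). Earlier compounds, all limits, could not show this. The step is only a floor because compound 3 reads as a limit: the limit of > 32 uM in this assay, at which 1 of the 4 values shown sits.

The compounds shown do not tell whether the entering oxygen or the loss of the tert-butyl carbons carries the step. An ethyl group or a dimethylamino group at this place would bear on that question.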